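The source may hold more compounds than are shown below. What is called first, only, known or untested is meant among the compounds shown, and "the series" means these compounds.

Measured so far in an ADME assay on L02 cells (Homo sapiens) for antiproliferative activity, read by MTT assay, with a stated time of 48 h; a higher number here means a weaker inhibitor, a lower number a stronger inhibitor:

Compound 1 `N#CC1=C(N)Oc2c(c3nc4ccccc4nc3c3ccccc23)C12C(=O)N(Cc1cnnn1-c1ccc(F)cc1)c1ccccc12` — > 50000 nM
Compound 2 `N#CC1=C(N)Oc2c(c3nc4ccccc4nc3c3ccccc23)C12C(=O)N(Cc1cnnn1-c1ccc([N+](=O)[O-])cc1)c1ccccc12` — > 50000 nM
Not yet measured: compound 3 `Cc1ccc(-n2nncc2CN2C(=O)C3(C(C#N)=C(N)Oc4c3c3nc5ccccc5nc3c3ccccc43)c3ccccc32)c(C)c1`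

Both reported values are limits of this assay, not numbers. For compound 1 the value > 50000 nM is such a limit. For compound 2 the value > 50000 nM is likewise a limit. Going by the values given here, the step that the two limits leave unreadable from compound 1 to compound 2 therefore cannot be read as a size; what the two values show is only that both compounds sit at the limit of > 50000 nM in this assay, at which 2 of the 2 values shown sit. Compound 2 thus stands at the limit of this assay, with no number of its own.

The change from compound 2 to compound 3 is 2,4-dimethylphenyl in place of 4-nitrophenyl on an aromatic nitrogen. Among the compounds with values here, the only measured step, from compound 1 to compound 2, is unreadable, so no step bears on this change with a known size. With compound 2 at the limit, compound 3 is expected to remain at or near the limit, and the step that the limit leaves unreadable from compound 2 to compound 3 is estimated to be none beyond the scatter. For compound 3 the estimate is 60000 nM, within a range from 25000 nM to 150000 nM.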

Compound 3, half-maximal inhibitory concentration: > 50000 nM
Compound 3: a limit, no number (the forecaster's own chance of this, stated with the estimate: 85%); the middle value lies beyond the limit too.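

Compound 3 also gives a limit and not a number, so no step among compound 1, compound 2 and compound 3 can be read: the limit of > 50000 nM in this assay, at which 3 of the 3 values shown sit.

The compounds shown leave open how 4-fluorophenyl, 4-nitrophenyl and 2,4-dimethylphenyl compare in this assay.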